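A few compounds are considered here, and "the series" means these few. Any claim that something is new, unique, unknown or untested is made for them only; others in the source may bear on it.

Measured in a functional assay on DU-145 cells (Homo sapiens) for inhibition, read by trypan blue exclusion, with a stated time of 96 h; a lower number here means a stronger inhibitor of growth, a higher number a weaker inhibitor of growth:

Compound 1 `Cc1ccc(S/C(=C/c2c[nH]c3ccccc23)C(=O)c2ccc(Br)cc2)cc1`: 10000 nM
Compound 2 `Cc1ccc(S/C(=C/c2cc(C)cc(C)c2)C(=O)c2ccc(Cl)cc2)cc1`: 50000 nM

Of these two, compound 2 has the higher number, which makes it the weaker inhibitor of growth, and its gap to compound 1 lies beyond the usual scatter. Compound 3 `Cc1ccc(S/C(=C/c2c[nH]c3ccccc23)C(=O)c2ccc(Cl)cc2)cc1` has not been measured yet. It differs from compound 2 in one place, with 1H-indol-3-yl in place of 3,5-dimethylphenyl on a double-bonded chain carbon bound to a double-bonded chain carbon. Going by the values given here, no measured pair shows this change on its own, so the only guide is compound 1, which also carries 1H-indol-3-yl and gives 10000 nM in this assay. The expected change is a 5.0-fold lower number from compound 2 to compound 3 (0.70 log units; beyond the scatter), toward stronger inhibition of growth. The estimate for compound 3 is 10000 nM, with an expected range of 3000 nM to 30000 nM.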

Compound 3, concentration for 50% growth inhibition: 10000 nM
Compound 3: the middle estimate sits on the measured number at the digits printed; measured number inside the range.
By their numbers in this assay, from the lowest: compounds 1 and 3 (each within the scatter of the next); then compound 2.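

Going by these compounds alone, compound 3 gives the first reading of this change on its own: in this assay, putting 1H-indol-3-yl in place of 3,5-dimethylphenyl on the double-bonded chain carbon gives a 5.0-fold lower number from compound 2 to compound 3 (0.70 log units; beyond the scatter) and so stronger inhibition of growth. Within the data shown here, it also allows the first one-place comparison of the halogens, and chloro in place of bromo on the aromatic carbon gives no change at the digits printed from compound 1 to compound 3 (within the scatter) so that, with 1H-indol-3-yl present, this read-out does not separate the two. No supporting measurement is available to explain either result.

The compounds shown leave open how an amine or a carboxylic acid would read on the double-bonded chain carbon. They also leave open whether a methoxy group in place of the halogen would keep the number seen with compound 3.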